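Ring methyl step carried from one core to another

The compounds below may be only part of what the source reports. "The series", "measured", "known", "first", "only" and "open" are said of these compounds alone.

Compound 1 `CCOC(=O)N(C)CC#CCn1ccnc1` and compound 2 `CCOC(=O)N(C)CC#CCn1cncc1C` share one core, while compound 3 `CN1CCN(CC#CCn2ccnc2)C1=O` is built on a different one; the difference between the two cores is not broken down here. In a functional assay on the whole organism for antagonist activity, with Mus musculus as the target (on this read-out higher numbers stand for an effect only at larger amounts of compound and lower numbers for an effect already at smaller amounts), compound 1 gives 97 mg/kg. In this assay compound 2 gives 66 mg/kg. For the measured compounds named here, the single change between them is methyl in place of hydrogen on an aromatic carbon, and it produced a 1.5-fold lower number from compound 1 to compound 2 (0.17 log units; within the scatter), so the pair reads as one value twice.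

In this assay compound 3 gives > 100 mg/kg, which is a limit of the assay and not a number, namely (the limit of > 100 mg/kg in this assay, at which 1 of the 3 values shown sits).

Compound 4 `Cc1cncn1CC#CCN1CCN(C)C1=O` has not been measured. It differs from compound 3 by methyl in place of hydrogen on an aromatic carbon; the group, what leaves and the place are word for word the same as in the pair above, so it is the same change made on the second core.

For compound 4 in this assay the expected step is a number no higher from compound 3 to compound 4 (the limit leaves the size open), set beside a 1.5-fold lower number from compound 1 to compound 2 (0.17 log units; within the scatter). The expectation rests on that measured step alone, carried over to a starting point that is itself only a limit. Compound 4 is estimated at 100 mg/kg in this assay, with a range from 50 mg/kg to 250 mg/kg. The range is wide because the limit of > 100 mg/kg in this assay, at which 1 of the 3 values shown sits, leaves compound 3 without a number, and a second limit is as likely as a value.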

Compound 4, dose for half-maximal effect: 14 mg/kg
Beside the measured number, compound 4's estimate is 7.1-fold (0.85 log units) above it; measured number outside the range, below it.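

In this assay, methyl in place of hydrogen on an aromatic carbon gives an at least 7.1-fold lower number from compound 3 to compound 4 (0.85 log units; beyond the scatter), so on these two pairs the step does not carry from one core to the other at one size: the same change on two cores in this assay, a 1.5-fold lower number (0.17 log units; within the scatter) from compound 1 to compound 2 and an at least 7.1-fold lower number (0.85 log units; beyond the scatter) from compound 3 to compound 4, at least 4.8-fold (0.68 log units) apart, beyond the scatter of two such steps

Compound 3 gives > 100 mg/kg, which is a limit of the assay and not a number: the limit of > 100 mg/kg in this assay, at which 1 of the 4 values shown sits.

The two pairs show that the size of this step differs with the core in these compounds, but they set no upper size for the step on the core of compound 3, give no reason for the gap and offer no rule for any further core.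

Open, going by these compounds, is whether the gap belongs to methyl alone or also appears with another group at the same place, such as ethyl, chlorine or trifluoromethyl, on both cores. Also open, on these data alone, is which part of the difference between the core of compound 1 and the core of compound 3 goes with the gap, since the two cores are compared here only as wholes and through a single pair each.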